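Aminotriazine coumarin ethers: chlorophenyl substitution and agonist potency

The compounds below may be only part of what the source reports. "The series", "measured", "known", "first", "only" and "open" are said of these compounds alone.

Measured so far:
compound 1 `Cc1cc(=O)oc2cc(OCc3nc(N)nc(Nc4cccc(Cl)c4)n3)ccc12` — 1110 nM
compound 2 `Cc1ccc(Nc2nc(N)nc(COc3ccc4c(C)cc(=O)oc4c3)n2)cc1Cl` — 140 nM
compound 3 `Cc1cc(=O)oc2cc(OCc3nc(N)nc(Nc4ccc(Cl)c(Cl)c4)n3)ccc12` — 780 nM

All three share one core and differ only on the aryl ring of the anilino group. In an assay on COS-7 cells for agonist activity at Free fatty acid receptor 1 (Homo sapiens), read by scintillation counting and inositol phosphate accumulation, with a stated time of 90 min (on this read-out lower numbers stand for an effect already at smaller amounts and higher numbers for an effect only at larger amounts of compound), compound 3 stands second highest of the three numbers; its nearest neighbour is compound 1 a 1.4-fold lower number from compound 1 to compound 3 (0.15 log units; within the scatter), the furthest is compound 2 a 5.6-fold higher number from compound 2 to compound 3 (0.75 log units; beyond the scatter). The other measured step, a 7.9-fold lower number from compound 1 to compound 2 (0.90 log units; beyond the scatter), shows that a methyl on this ring can lower the number markedly.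

Compound 4 `Cc1cc(Nc2nc(N)nc(COc3ccc4c(C)cc(=O)oc4c3)n2)ccc1Cl` differs from compound 3 by methyl in place of chloro on an aromatic carbon. The step from compound 2 to compound 3 is the same pair of groups exchanged the other way, and compound 4 carries, like compound 2, one chloro and one methyl on that ring, arranged differently. An exact precedent for this spot is lacking. A modest lowering of the number is therefore expected, a 2.2-fold lower number from compound 3 to compound 4 (0.35 log units; beyond the scatter), short of what compound 2 gives. For compound 4 the estimate in this assay is 350 nM, with a range from 120 nM to 1000 nM.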

Compound 4, half-maximal effective concentration: 240 nM
Beside the measured number, compound 4's estimate is 1.5-fold (0.16 log units) above it, and the stated range covers the measured number.
By their numbers in this assay, from the lowest: compounds 2 and 4 (each within the scatter of the next); then compounds 3 and 1 (each within the scatter of the next).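

In this assay the change from 3,4-dichlorophenyl to 4-chloro-3-methylphenyl gives a 3.3-fold lower number from compound 3 to compound 4 (0.51 log units; beyond the scatter) and shows that the gain seen with a methyl on this ring also holds with a methyl ortho to a chloro group. Set against the 3-chlorophenyl ring, the same group gives a 4.6-fold lower number from compound 1 to compound 4 (0.67 log units; beyond the scatter) while exchanging the chloro and methyl places on the ring gives a 1.7-fold higher number from compound 2 to compound 4 (0.23 log units; within the scatter) so the two arrangements of one chloro and one methyl cannot be told apart on this read-out. No measurement at hand explains why methyl and chloro differ at this place.

From the compounds shown here alone, whether the lower numbers are specific to methyl, or would persist with an ethyl, methoxy or trifluoromethyl group at that place, remains open. Also open, going by these compounds, is whether a 3-methylphenyl ring carrying no chloro would keep them.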